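The source may report more compounds than this note shows. Statements on the series, on what has been measured and on what is new or still open speak of the compounds shown alone.

In a functional assay on HCT-8 cells (Homo sapiens) for antiproliferative activity, read by MTT assay, with a stated time of 48 h (on this read-out lower numbers stand for stronger inhibition and higher numbers for weaker inhibition), compound 2 (`C=C(c1ccc(OC)cc1NC(=O)CNC)c1ccc(OC)c2c1OC(C)(C)C=C2`) gives 320 nM. That value lies within the usual scatter of compound 1 (`C=C(c1ccc(OC)cc1NC(=O)CN)c1ccc(OC)c2c1OC(C)(C)C=C2`), which gives 190 nM, and clearly under compound 3 (`C=C(c1ccc(OC)cc1NC(=O)CNC)c1ccc(OC)c2c1C=CC(C)(C)O2`), which gives 980 nM. Compound 4 (`C=C(c1ccc(OC)cc1NC(=O)CN(C)C)c1ccc(OC)c2c1OC(C)(C)C=C2`) differs from compound 2 by a single change: methyl in place of hydrogen on an amine nitrogen. This is methyl in place of hydrogen on an amine nitrogen, turning methylamino into dimethylamino. Among the measured compounds shown here, the only measured step of the same kind is a 1.7-fold higher number from compound 1 to compound 2 (0.23 log units; within the scatter), and it stays within the scatter. On that evidence, a second methyl is expected to cause no step beyond the scatter in this assay. The expected step is a 1.3-fold higher number from compound 2 to compound 4 (0.10 log units; within the scatter). For compound 4 the estimated value is 400 nM, with an expected range of 150 nM to 1100 nM.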

Compound 4, half-maximal inhibitory concentration: 690 nM
Compound 4: middle estimate off by 1.7-fold (0.24 log units), on the low side; measured number inside the range.
By their numbers in this assay, from the lowest: compounds 1 and 2 (each within the scatter of the next); then compounds 4 and 3 (each within the scatter of the next).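

In this assay, the amine nitrogen tolerates a first methyl within the scatter, but a second methyl gives a 2.2-fold higher number from compound 2 to compound 4 (0.33 log units; beyond the scatter) and so reaches past it. Counted from the unsubstituted amine, dimethylamino in place of amino gives a 3.6-fold higher number from compound 1 to compound 4 (0.56 log units; beyond the scatter) and inhibition weakens modestly but is not lost. No available evidence explains this loss.

The compounds shown leave open whether an ethyl group on this nitrogen would raise the number further. They also leave open how a pyrrolidine ring, which would hold the nitrogen within a ring, would compare.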